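The source may report more compounds than this note shows. Statements on the series, on what has been measured and on what is new or still open speak of the compounds shown alone.

In a physicochemical assay for solubility (a higher number here means a more soluble compound, a lower number a less soluble compound), compound 3 `CNC(=O)c1cc(C(=O)NC2CC2)cn(Cc2cccc([C@@H](C)O)c2)c1=O` gives only a limit, >= 131 ug/mL. Compound 1 `CNC(=O)c1cc(C(=O)NC2CC2)cn(Cc2ccc(OC)cc2)c1=O` also gives only a limit, >= 143 ug/mL. Compound 2 `CNC(=O)c1cc(C(=O)NC2CC2)cn(Cc2cccc(F)c2)c1=O` likewise gives a limit, >= 133 ug/mL. Compound 4 `CNC(=O)c1cc(C(=O)NC2CC2)cn(Cc2cccc3[nH]ncc23)c1=O` keeps the shared core but carries 1H-indazol-4-yl in place of 3-(1-hydroxyethyl)phenyl on a saturated chain carbon bound to an aromatic nitrogen. Two measured swaps at that place bear on this change: a step that the two limits leave unreadable from compound 1 to compound 2 and a step that the two limits leave unreadable from compound 1 to compound 3. Neither shows a readable size or direction, so no step beyond the scatter is expected in this assay. The expected step is a number no higher from compound 3 to compound 4 (the limit leaves the size open). For compound 4 the estimated value is 130 ug/mL, with an expected range from 70 ug/mL to 200 ug/mL.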

Compound 4, solubility: 10 ug/mL
Beside the measured number, compound 4's estimate is 13-fold (1.11 log units) above it, outside the stated range (below it).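

In this assay, going by these compounds alone, the swap to 1H-indazol-4-yl on this saturated chain carbon gives an at least 13-fold lower number from compound 3 to compound 4 (1.11 log units; beyond the scatter) and an at least 13-fold lower number from compound 2 to compound 4 (1.12 log units; beyond the scatter) and an at least 14-fold lower number from compound 1 to compound 4 (1.15 log units; beyond the scatter) as the first readable steps at this place. Within the data shown here, compounds 1, 2 and 3 each give only a limit, and the steps among them cannot be read, so the earlier swaps gave no sign that this place could move the number so far. Nothing shown gives a cause for this drop. Still open, going by these compounds, is whether the fused five-membered ring or its two nitrogens carry the drop. Also open, on these data alone, is how a phenyl ring bearing an amine or a carboxylic acid would compare with compound 4.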